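This account rests on a few compounds, and the source may have more. Where it says the series, first, only, none or still open, it means among the compounds named here.

Compound 2 `COc1cc(-c2nn(-c3cccc(NC(=O)Nc4cccc(C(F)(F)F)c4)c3)cc2-c2ccncc2)ccc1Cl` is a urea-linked analogue. In a functional assay on SK-MEL-5 cells (Homo sapiens) for inhibition, read by sulforhodamine B assay, with a stated time of 48 h (a lower number here means a stronger inhibitor of growth, a higher number a weaker inhibitor of growth), compound 2 gives 1390 nM. Among the two compounds measured, compound 2 carries the lower number, but it sits within the scatter of compound 1 `COc1cc(-c2nn(-c3cccc(NC(=O)Nc4ccc(Cl)c(Cl)c4)c3)cc2-c2ccncc2)ccc1Cl`, which in this assay gives 1490 nM. Within the data shown here, the only measured step, a 1.1-fold lower number from compound 1 to compound 2 (0.03 log units; within the scatter), exchanges one aryl group for another on the amide-type nitrogen and changes nothing beyond the scatter.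

Compound 3 `COc1cc(-c2nn(-c3cccc(NC(=O)c4ccc(Cl)c(C(F)(F)F)c4)c3)cc2-c2ccncc2)ccc1Cl` departs from compound 2 by 4-chloro-3-(trifluoromethyl)phenyl in place of (3-(trifluoromethyl)phenyl)amino on a carbonyl carbon, so the urea linkage becomes a plain amide while the aryl end is also altered. Among the measured compounds shown here, no measured step touches this kind of change, and the one step that exists bears only on the aryl end. The expectation is therefore that compound 3 lands near compound 2, with a 1.1-fold higher number from compound 2 to compound 3 (0.03 log units; within the scatter) as the estimated step, and a wide range to reflect the missing precedent. The estimated value for compound 3 in this assay is 1500 nM, expected between 500 nM and 4500 nM.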

Compound 3, concentration for total growth inhibition: 6870 nM
Compound 3: middle estimate off by 4.6-fold (0.66 log units), on the low side; measured number above the stated range.
By their numbers in this assay, from the lowest: compounds 2 and 1 (each within the scatter of the next); then compound 3.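

In this assay, putting 4-chloro-3-(trifluoromethyl)phenyl in place of (3-(trifluoromethyl)phenyl)amino on the carbonyl carbon gives a 4.9-fold higher number from compound 2 to compound 3 (0.69 log units; beyond the scatter), and putting it in place of (3,4-dichlorophenyl)amino gives a 4.6-fold higher number from compound 1 to compound 3 (0.66 log units; beyond the scatter) as well. Unlike the earlier exchange of one aryl group for another within the ureas, this change moves the number beyond the scatter, towards a weaker inhibitor of growth, and it holds for both urea starting points. No measurement here offers an explanation for this rise.

The change removes the amino nitrogen and alters the aryl end at once, so the compounds shown cannot separate the two effects. On these data alone, it also stays open how this position would respond if a methylene group or a sulfonamide linked the aryl ring to the core.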